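A few compounds are considered here, and "the series" means these few. Any claim that something is new, unique, unknown or untested is made for them only; others in the source may bear on it.

The study follows a small set built on a shared core. Compound 1 `N#C/N=C1\N(CCCCCCOc2ccc(Cl)cc2)C(=O)CN1c1ccncc1` gives 2960 nM in a functional assay on HONE1 cells for cytotoxicity against HONE1 cell line (Homo sapiens); on this read-out higher numbers stand for weaker inhibition and lower numbers for stronger inhibition. Among the compounds with values here, compound 2 `N#C/N=C1\N(CCCCCOc2ccc(Cl)cc2)C(=O)C(c2ccccc2)N1c1ccncc1` gives 373 nM in this assay, the lowest of the two numbers on hand; its only neighbour is compound 1, whose number is higher by a margin beyond the usual scatter. These two compounds differ from each other in more than one place, so the share of each change in that gap cannot be read from the numbers alone.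

Compound 3 `N#C/N=C1\N(CCCCCCOc2ccc(Cl)cc2)C(=O)C(c2ccccc2)N1c1ccncc1` has not been measured. It differs from compound 2 by a single alteration: (4-chlorophenoxy)methyl in place of 4-chlorophenoxy on a saturated chain carbon, five bonds along the chain from an amide-type nitrogen in a ring. The effect of this longer chain on its own is not shown by any measured pair, and the two measured compounds are set apart by more than this change. Compound 3 is therefore expected to sit close to compound 2 in this assay. The expected step is a 1.1-fold higher number from compound 2 to compound 3 (0.05 log units; within the scatter), which is not expected to go beyond the scatter in either direction. For compound 3 the estimate in this assay is 420 nM, ranging from 150 nM to 1200 nM.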

Compound 3, half-maximal inhibitory concentration: 337 nM
For compound 3 the middle estimate is 1.2-fold (0.10 log units) above the measured one; low and high end bracket the measured number.
By their numbers in this assay, from the lowest: compounds 3 and 2 (each within the scatter of the next); then compound 1.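

In this assay, (4-chlorophenoxy)methyl in place of 4-chlorophenoxy on a saturated chain carbon, five bonds along the chain from an amide-type nitrogen in a ring, gives a 1.1-fold lower number from compound 2 to compound 3 (0.04 log units; within the scatter), so with the phenyl in place, the two chain lengths of compound 2 and compound 3 cannot be told apart at this position. Within the data shown here, the pair that shares the longer chain now gives the first single-place reading of phenyl in place of hydrogen on a saturated ring carbon, an 8.8-fold lower number from compound 1 to compound 3 (0.94 log units; beyond the scatter), a step that lies beyond the scatter, whereas the earlier pair of compounds changed in more than one place. Nothing on hand gives a reason for either step.

The compounds shown leave open whether the chain change stays as small on a core without the phenyl, and whether a still longer chain, with 2-(4-chlorophenoxy)ethyl or 3-(4-chlorophenoxy)propyl at this place, also stays within the scatter. They also leave open whether a methyl or a benzyl on the saturated ring carbon gives a step like that of phenyl.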